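Notes on compound 4: methoxy for (carboxymethyl)amino

A few compounds are considered here, and "the series" means these few. Any claim that something is new, unique, unknown or untested is made for them only; others in the source may bear on it.

Values in an ADME assay on KB cells (Homo sapiens) for cytotoxicity, with a stated time of 48 h; on this read-out higher numbers stand for weaker inhibition and lower numbers for stronger inhibition:
compound 1 `C=C1[C@H](C)CCC[C@]1(C)CC/C(C)=C/CC1=C(O)C(=O)C=C(N[C@@H](C(=O)O)C(C)C)C1=O`: 6.2 ug/mL
compound 2 `C=C1[C@H](C)CCC[C@]1(C)CC/C(C)=C/CC1=C(O)C(=O)C=C(N[C@H](C(=O)O)[C@@H](C)O)C1=O`: > 10 ug/mL (a limit of the assay, not a number)
compound 3 `C=C1[C@H](C)CCC[C@]1(C)CC/C(C)=C/CC1=C(O)C(=O)C=C(NCC(=O)O)C1=O`: 4 ug/mL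

In this assay compound 3 stands level with compound 1 within the scatter: a 1.6-fold lower number from compound 1 to compound 3 (0.19 log units; within the scatter). Against the limit of compound 2 the gap is clearer: an at least 2.5-fold lower number from compound 2 to compound 3 (0.39 log units; beyond the scatter).

Compound 4 `C=C1[C@H](C)CCC[C@]1(C)CC/C(C)=C/CC1=C(O)C(=O)C=C(OC)C1=O` has methoxy in place of (carboxymethyl)amino on a double-bonded ring carbon. The measured steps bear on this only indirectly. All of them alter the chain on the amine nitrogen and keep the nitrogen itself, and the third, an at least 1.6-fold higher number from compound 1 to compound 2 (0.20 log units; that floor lies within the scatter), also rests on the limit. Going by the values given here, no measured compound carries methoxy, so the direction in this assay stays open and no step beyond the scatter is expected, though with wide uncertainty. The expected step is a 1.3-fold lower number from compound 3 to compound 4 (0.12 log units; within the scatter). The estimate for compound 4 is 3 ug/mL, with an expected range of 1 ug/mL to 8 ug/mL.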

Compound 4, half-maximal inhibitory concentration: > 10 ug/mL
Compound 4: no number, only a limit; the forecaster's own chance of this, stated with the estimate: 10%; middle value at least 3.3-fold (0.52 log units) from the limit.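

Earlier steps all kept the nitrogen on this double-bonded ring carbon and altered only its chain. Exchanging the whole (carboxymethyl)amino for methoxy in this assay gives an at least 2.5-fold higher number from compound 3 to compound 4 (0.39 log units; beyond the scatter), so the level of compound 3 does not survive this change. From (1-carboxy-2-methylpropyl)amino, the exchange gives an at least 1.6-fold higher number from compound 1 to compound 4 (0.20 log units; that floor lies within the scatter), which alone settles little, and the step between compound 2 and compound 4 cannot be read, as each compound carries only a limit.

Going by these compounds, the size of the rise from compound 3 stays unknown because the read-out ends in a limit: the limit of > 10 ug/mL in this assay, at which 2 of the 4 values shown sit. On these data alone, whether a plain alkylamine without the carboxylic acid, or a longer alkoxy chain, on this ring carbon would stay level with compound 3 remains open.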